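This account rests on a few compounds, and the source may have more. Where it says the series, first, only, none or still open, it means among the compounds named here.

Working notes on the series. Three measured analogues share one core and differ only in the aryl group on the carbon with a double bond to nitrogen. In an ADME assay on NIH3T3 cells (Mus musculus) for cytotoxicity, read by MTT assay, with a stated time of 24 h (on this read-out higher numbers stand for weaker inhibition and lower numbers for stronger inhibition), compound 1 `O=C(CSc1nnc(-c2ccncc2)o1)N/N=C/c1ccc(Br)cc1` gives 169000 nM, compound 2 `O=C(CSc1nnc(-c2ccncc2)o1)N/N=C/c1ccc(O)cc1` gives 158000 nM, and compound 3 `Cc1ccc(/C=N/NC(=O)CSc2nnc(-c3ccncc3)o2)cc1` gives 185000 nM. Of the three numbers, that of compound 3 is the highest, yet every step to it lies within the scatter: a 1.1-fold higher number from compound 1 to compound 3 (0.04 log units; within the scatter), a 1.2-fold higher number from compound 2 to compound 3 (0.07 log units; within the scatter), and likewise a 1.1-fold lower number from compound 1 to compound 2 (0.03 log units; within the scatter). The three compounds therefore read as indistinguishable in this assay.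

Compound 4 `O=C(CSc1nnc(-c2ccncc2)o1)N/N=C/c1ccccc1[N+](=O)[O-]` is not yet measured. From compound 3 it differs by 2-nitrophenyl in place of 4-methylphenyl on a carbon with a double bond to nitrogen. Among the compounds with values here, no measured pair covers a nitro group; the steps that bear on the change are the three exchanges of the group on the aryl ring noted above, each of which left this assay unchanged within the scatter. On that basis the step expected here is none beyond the scatter: a 1.1-fold lower number from compound 3 to compound 4 (0.04 log units; within the scatter). Within the data shown here, compound 4 is accordingly estimated at 170000 nM in this assay, with a range of 85000 nM to 340000 nM; the range is kept wide, as the entering group has no measured counterpart.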

Compound 4, half-maximal inhibitory concentration: 214000 nM
Estimate against measurement, compound 4: 1.3-fold (0.10 log units) below, within the range that was stated.
By their numbers in this assay, from the lowest: compounds 2, 1, 3 and 4 (each within the scatter of the next).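

In this assay, 2-nitrophenyl on a carbon with a double bond to nitrogen stays within the scatter of all three earlier aryl groups, whether it replaces 4-methylphenyl (a 1.2-fold higher number from compound 3 to compound 4 (0.06 log units; within the scatter)), 4-hydroxyphenyl (a 1.4-fold higher number from compound 2 to compound 4 (0.13 log units; within the scatter)) or 4-bromophenyl (a 1.3-fold higher number from compound 1 to compound 4 (0.10 log units; within the scatter)). The tolerance seen so far among the three earlier aryl groups therefore extends to a larger group, with 9 heavy atoms against 7 for 4-methylphenyl and 2 hydrogen-bond acceptors against 0, and to a ring whose substituent is named at the 2 position rather than the 4 position. Nothing available explains why these exchanges leave the number within the scatter.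

Going by these compounds, all four compounds keep a six-membered aromatic ring of carbon only at this place, so it remains open whether a saturated ring or a longer alkyl chain in its stead would shift the number in this assay beyond the scatter. Also open, on these data alone, is whether an amine or a carboxylic acid on the aryl ring, or 4-nitrophenyl in place of 2-nitrophenyl, would do so.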